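This account rests on a few compounds, and the source may have more. Where it says the series, first, only, none or still open, it means among the compounds named here.

The study centres on an assay on CHO cells for inhibition of Vasopressin V2 receptor (Homo sapiens), read by radioligand binding; on this read-out higher numbers stand for weaker inhibition and lower numbers for stronger inhibition. Compound 1, `O=C(Nc1ccc(C(=O)N2CCCCc3sccc32)cc1OCCCC(=O)N1CCC(N2CCCCC2)CC1)c1ccccc1-c1ccccc1`, gives 30 nM in this assay. Compound 2, `O=C(Nc1ccc(C(=O)N2CCCN(CCN3CCCC3)c3sccc32)cc1)c1ccccc1-c1ccccc1`, gives 200 nM in this assay. Compound 3, `O=C(Nc1ccc(C(=O)N2CCCCc3sccc32)cc1O)c1ccccc1-c1ccccc1`, is recorded in this assay only as a limit, < 10 nM, and that reading is a limit of the assay rather than a number, as the limit of < 10 nM in this assay, at which 1 of the 3 values shown sits, records. Of the two values that are numbers, compound 1 holds the lower one; compound 2 sits a good deal higher, and that gap lies beyond the usual scatter of repeated measurements.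

Compound 4, `CN(C)C1CCN(C(=O)CCCOc2cc(C(=O)N3CCCCc4sccc43)ccc2NC(=O)c2ccccc2-c2ccccc2)CC1`, has not yet been measured in this assay. It differs from compound 1 in one place: dimethylamino in place of piperidin-1-yl on a saturated ring carbon. The change sits on a saturated ring carbon of a six-membered non-aromatic ring with one nitrogen, three ring bonds from the ring nitrogen; cut one bond further out, it reads 4-(piperidin-1-yl)piperidin-1-yl to 4-(dimethylamino)piperidin-1-yl. Going by the values given here, no measured pair in this set tracks that change, so the expectation rests on compound 1 alone. The step is expected to be small, most likely within the scatter, with a slight lean toward a higher number, as a 1.3-fold higher number from compound 1 to compound 4 (0.12 log units; within the scatter) expresses. Compound 4 is therefore estimated to give 40 nM in this assay, expected to fall between 12 nM and 130 nM.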

Compound 4, half-maximal inhibitory concentration: 20 nM
Compound 4: middle estimate off by 2.0-fold (0.30 log units), on the high side; low and high end bracket the measured number.
By their numbers in this assay, from the lowest: compounds 4 and 1 (each within the scatter of the next); then compound 2. At a limit, below all of these: compound 3.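

Going by these compounds alone, compound 1 and compound 4 form the first pair in the set that can be read at this position, and in this assay the exchange of 4-(piperidin-1-yl)piperidin-1-yl for 4-(dimethylamino)piperidin-1-yl gives a 1.5-fold lower number from compound 1 to compound 4 (0.18 log units; within the scatter). On this read-out, therefore, the saturated ring carbon three ring bonds from the ring nitrogen can carry either the ringed piperidin-1-yl or the open dimethylamino, which has fewer heavy atoms, and the two compounds cannot be told apart. Nothing shown here bears on why the two groups read alike.

What the compounds leave open is how far this indifference extends, since both groups tested at this ring carbon are tertiary amines with a single nitrogen and no hydrogen-bond donor. A primary amine, a morpholin-4-yl ring, a carboxylic acid or a plain hydrogen at the same carbon could each show whether the amine nitrogen matters here at all, and a single pair cannot say whether the same exchange would read alike on a shorter or longer chain.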